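The compounds below may be only part of what the source reports. "The series", "measured", "known", "first", "only" and "open" are said of these compounds alone.

Measured compounds:
compound 1, `O=C1COc2ccc(-c3cccc(NS(=O)(=O)c4ccc(F)cc4)c3)cc2N1C1CC1` — > 40000 nM
compound 2, `O=C1COc2ccc(-c3cnc(Cl)c(NS(=O)(=O)c4ccc(F)cc4)c3)cc2N1C1CCCCC1` — > 40000 nM
compound 3, `COc1ncc(-c2ccc3c(c2)N(C2CCCCC2)C(=O)CO3)cc1NS(=O)(=O)c1ccc(F)cc1` — > 40000 nM

In a functional assay on HepG2 cells (Homo sapiens) for antiproliferative activity, read by MTT assay, with a stated time of 72 h (on this read-out lower numbers stand for stronger inhibition and higher numbers for weaker inhibition), compound 1 gives only a limit, > 40000 nM. Compound 2 likewise gives a limit, > 40000 nM. Compound 3 likewise gives a limit, > 40000 nM. All three sit at the limit of > 40000 nM in this assay, at which 3 of the 3 values shown sit, so compound 1 stands at the limit of this assay, as do compound 2 and compound 3, both of which carry a cyclohexyl on the amide-type nitrogen. Among the measured compounds shown here, the sole step between measured compounds, a step that the two limits leave unreadable from compound 2 to compound 3, runs between two limits and cannot be read. Compound 4, `O=C1COc2ccc(-c3cccc(NS(=O)(=O)c4ccc(F)cc4)c3)cc2N1C1CCCCC1`, differs from compound 1 in cyclohexyl in place of cyclopropyl on an amide-type nitrogen in a ring. For the measured compounds named here, no measured step bears directly on this change; compound 2 and compound 3 show only that cyclohexyl at this position also sits at the limit. Compound 4 is therefore expected to remain at the limit, estimated at 60000 nM (range 20000 nM to 200000 nM). The expected step that the limit leaves unreadable from compound 1 to compound 4 is thus none readable beyond the scatter.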

Compound 4, half-maximal inhibitory concentration: 35900 nM
For compound 4 the middle estimate is 1.7-fold (0.22 log units) above the measured one; low and high end bracket the measured number.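

In this assay compound 4 gives a readable number, 35900 nM. The earlier compounds shown here give only limits. With cyclohexyl in place of cyclopropyl on the amide-type nitrogen in a ring, the step reads an at least 1.1-fold lower number from compound 1 to compound 4 (0.04 log units; that floor lies within the scatter), so this change shows no effect beyond the scatter. The value of compound 1 is still only a limit, as are most values in the set: the limit of > 40000 nM in this assay, at which 3 of the 4 values shown sit.

Open, on these data alone, is whether an amine, a carboxylic acid or a longer chain on this nitrogen would give a number clearly away from that limit.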